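The compounds below may be only part of what the source reports. "The series", "measured", "known", "first", "only" and "open" are said of these compounds alone.

Of the compounds shown here, two have been tested so far in a functional assay on MCF7 cells (Homo sapiens) for antiproliferative activity; on this read-out lower numbers stand for stronger inhibition and higher numbers for weaker inhibition. Compound 1 (`COC(=O)c1ccc(C/C=C(\C)CCC(=O)O)[nH]1`) gives > 100000 nM, which is a limit of the assay and not a number. Compound 2 (`C/C(=C\Cn1cnc2c(Cl)ncnc21)CCC(=O)O`) gives > 100000 nM, which is also a limit and not a number. Within the data shown here, compound 2 therefore stands at the limit of > 100000 nM in this assay, at which 2 of the 2 values shown sit, and no measured step is available as a guide. Compound 3 (`C/C(=C\Cn1cnc2c(O)ncnc21)CCC(=O)O`) differs from compound 2 in one place, with hydroxy in place of chloro on an aromatic carbon. The change sits on a six-membered aromatic ring with 2 nitrogen, part of a fused or bridged system of two rings. In this assay, among the measured compounds shown here, no change beyond the usual scatter is expected, and the only guide is compound 2 with its limit of > 100000 nM. The expected step is a number no higher from compound 2 to compound 3 (the limit leaves the size open). For compound 3 the estimated value is 100000 nM, with an expected range from 40000 nM to 200000 nM.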

Compound 3, half-maximal inhibitory concentration: > 100000 nM
Compound 3 was reported as a limit (the forecaster's own chance of this, stated with the estimate: 85%); the middle value sits exactly at the limit.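

Compound 2 and compound 3 are both reported only as limits in this assay, so no step can be read from the change of chloro to hydroxy: the limit of > 100000 nM in this assay, at which 3 of the 3 values shown sit.

The compounds shown leave open whether hydroxy and chloro differ at all in inhibition, and which structural change would give a measurable number.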